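The source may report more compounds than this note shows. Statements on the series, on what has been measured and on what is new or still open speak of the compounds shown alone.

Three ureas have been measured in an ADME assay on the whole organism with Oryza sativa as the target, tested at 10 uM; a lower number here means a stronger effect, a higher number a weaker effect of the compound at the concentration tested. Compound 1 `CC(C)c1ccccc1NC(=O)N[C@@H](C)c1ccccc1` gives 93%, compound 2 `COc1ccccc1NC(=O)N[C@H](C)c1ccccc1` gives 96%, and compound 3 `COc1ccccc1NC(=O)N[C@@H](C)c1ccccc1` gives 95%, the second highest of the three numbers, all three lying within the usual scatter of one another. Compound 4 `C[C@H](NC(=O)Nc1ccccc1I)c1ccccc1` differs from compound 3 in one place: iodo in place of methoxy on an aromatic carbon. Among the compounds with values here, two measured steps bear on this change. Replacing one ring substituent by another gave a number 2 percentage points higher from compound 1 to compound 3 (within the scatter), and a change of configuration alone gave a number 1 percentage points lower from compound 2 to compound 3 (within the scatter), a result that is unsurprising because of the fact that compounds 2 and 3 differ only in the configuration as drawn. Neither step hints at a shift beyond the scatter, so the step of a number 4 percentage points lower from compound 3 to compound 4 (within the scatter) is expected to be small. Compound 4 is therefore estimated at 91%, between 76% and 100%.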

Compound 4, a percentage reported as activity, at one concentration (the size of the read-out at that concentration, not a potency): 98%
The estimate for compound 4 lay 7 percentage points below the measured number; the measured number falls inside the stated range.
By their numbers in this assay, from the lowest: compounds 1, 3, 2 and 4 (each within the scatter of the next).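

Iodo in place of methoxy on this aromatic carbon, ortho to a large group, gives a number 3 percentage points higher from compound 3 to compound 4 (within the scatter), and iodo in place of isopropyl gives a number 5 percentage points higher from compound 1 to compound 4 (within the scatter) in this assay. Iodo therefore joins methoxy and isopropyl as a third group at this position without a step beyond the scatter, even though the hydrogen-bond acceptor of methoxy is lost. Nothing at hand explains these small steps.

On these data alone, whether an amine or a carboxylic acid here would move the number beyond the scatter remains open. So does the effect of iodo with the opposite configuration as drawn.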